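Swapping the aryl ether in a triazole sulfanylacetamide series

This account rests on a few compounds, and the source may have more. Where it says the series, first, only, none or still open, it means among the compounds named here.

Compound 1 `Cc1ccc(C(C)C)c(OCc2nnc(SCC(=O)Nc3ccc(S(N)(=O)=O)cc3)n2Cc2ccccc2)c1`: 13 ug/mL
Compound 2 `Cc1ccc(C(C)C)c(OCc2nnc(SCC(=O)Nc3ccc(Br)cc3)n2Cc2ccccc2)c1`: 66.7 ug/mL
Compound 3 `CCOC(=O)c1ccc(NC(=O)CSc2nnc(COc3cc(C)ccc3C(C)C)n2Cc2ccccc2)cc1`: 19.8 ug/mL

In a toxicity assay on MT4 cells (Homo sapiens) for cytotoxicity, read by MTT assay, with a stated time of 5 days (on this read-out higher numbers stand for lower toxicity in this test and lower numbers for higher toxicity in this test), compound 1 gives the lowest of the three numbers. Its nearest neighbour is compound 3, the step of a 1.5-fold higher number from compound 1 to compound 3 (0.18 log units; within the scatter) staying within the scatter, while a 5.1-fold higher number from compound 1 to compound 2 (0.71 log units; beyond the scatter) and a 3.4-fold lower number from compound 2 to compound 3 (0.53 log units; beyond the scatter) are modest steps beyond it. All three of those steps change the group on the aromatic ring of the amide, not the ether end. Compound 4 `CC(=O)Nc1ccc(OCc2nnc(SCC(=O)Nc3ccc(S(N)(=O)=O)cc3)n2Cc2ccccc2)cc1` differs from compound 1 at that other end: 4-acetamidophenyl in place of 2-isopropyl-5-methylphenyl on an oxygen on a saturated carbon. Among the compounds with values here, no measured step touches this position, so the expectation rests on compound 1 alone and carries a wide range. Compound 4 is expected to give 20 ug/mL (range 7 ug/mL to 60 ug/mL) in this assay, a step of a 1.5-fold higher number from compound 1 to compound 4 (0.19 log units; within the scatter) that is estimated rather than supported by a measured precedent.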

Compound 4, half-maximal cytotoxic concentration: > 125 ug/mL
Compound 4: a limit, no number; the forecaster's own chance of this, stated with the estimate: 15%; middle value at least 6.2-fold (0.79 log units) from the limit.
By their numbers in this assay, from the lowest: compounds 1 and 3 (each within the scatter of the next); then compound 2. At a limit, above all of these: compound 4.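

The earlier compounds shown here changed only the group on the aromatic ring of the amide, whereas this result shows that the ether end also moves the number in this assay: 4-acetamidophenyl in place of 2-isopropyl-5-methylphenyl gives an at least 9.6-fold higher number from compound 1 to compound 4 (0.98 log units; beyond the scatter). Even as a lower bound, this step exceeds those seen at the amide end. Compound 4 stands at a limit, not a number: the limit of > 125 ug/mL in this assay, at which 1 of the 4 values shown sits.

Still open, from the compounds shown here alone, is whether gaining the acetamido group or losing the isopropyl and methyl groups matters more. A plain phenyl or a 4-aminophenyl at this position would help separate the two.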